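This account rests on a few compounds, and the source may have more. Where it says the series, first, only, none or still open, it means among the compounds named here.

Measured so far:
- compound 1 `C=CCCCCOc1cc(F)ccc1-c1cnc(OCCC=C)n1C`: 59000 nM
- compound 2 `CCCCCCOc1ncc(-c2ccccc2OC)n1C`: 27000 nM

In a functional assay on MCF7 cells (Homo sapiens) for inhibition, read by colorimetric assay and MTT assay, with a stated time of 72 h (a higher number here means a weaker inhibitor, a lower number a stronger inhibitor), compound 2 gives 27000 nM. This is the lower of the two numbers, and its gap to compound 1 lies beyond the scatter. The two compounds differ in more than one place, so that gap cannot be tied to any single change.

The next compound, compound 3 `C=CCCCCOc1ncc(-c2ccccc2OC)n1C`, differs from compound 2 in one place only: vinyl in place of ethyl on a saturated chain carbon, four bonds along the chain from an oxygen on an aromatic ring.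

Going by the values given here, no measured pair shows this change alone, so there is no direct guide. In this assay a step within the scatter, in neither direction, is expected. Compound 3 is estimated at 29000 nM, with an expected range from 13000 nM to 62000 nM. This estimate means a 1.1-fold higher number from compound 2 to compound 3 (0.03 log units; within the scatter).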

Compound 3, half-maximal inhibitory concentration: 5000 nM
Beside the measured number, compound 3's estimate is 5.8-fold (0.76 log units) above it; the measured number lies below the stated range.
By their numbers in this assay, from the lowest: compound 3; then compound 2; then compound 1.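

Vinyl in place of ethyl on a saturated chain carbon, four bonds along the chain from an oxygen on an aromatic ring, gives a 5.4-fold lower number from compound 2 to compound 3 (0.73 log units; beyond the scatter) in this assay. Going by these compounds alone, this is the first single change that can be read here, and it shows that the far end of this chain is not a neutral place: both groups have the same count of heavy atoms, all carbon, yet the number moves beyond the scatter. The only difference counted between the two groups is the double bond, and nothing available explains why this change has such an effect.

On these data alone, it remains open whether the step depends on the double bond itself or would also appear with an ethynyl group, a longer chain or an amine at this chain end. Whether vinyl gives a similar step on a different core also stays unanswered.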